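This account rests on a few compounds, and the source may have more. Where it says the series, first, only, none or still open, it means among the compounds named here.

Measured so far in a functional assay on A549 cells (Homo sapiens) for cytotoxicity, read by sulforhodamine B assay; on this read-out lower numbers stand for stronger inhibition and higher numbers for weaker inhibition:
Compound 1 `Oc1nc(-c2ccccc2)cc2ccccc12`: 5750 nM
Compound 2 `Cc1ccc(-c2cc3ccccc3c(O)n2)cc1`: 30200 nM

Compound 2, at 30200 nM, holds the higher of the two numbers and is therefore the weaker inhibitor of the pair. Compound 3 `Cc1ccc(-c2cc3cc(C)ccc3c(O)n2)cc1` differs from it by one change: methyl in place of hydrogen on an aromatic carbon. This is a methyl in place of hydrogen on an aromatic carbon, on the six-membered aromatic ring of carbon only that is part of a fused or bridged system of two rings. Among the compounds with values here, only one measured step bears on this change: a 5.3-fold higher number from compound 1 to compound 2 (0.72 log units; beyond the scatter). That step is the same kind of swap, but at a different place on the molecule, so it is a thin guide. A smaller rise in this assay is expected, possibly within the scatter. The expected change is a 1.5-fold higher number from compound 2 to compound 3 (0.17 log units; within the scatter). Compound 3 is estimated at 45000 nM, with an expected range of 15000 nM to 120000 nM.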

Compound 3, half-maximal inhibitory concentration: 5620 nM
Estimate against measurement, compound 3: 8.0-fold (0.90 log units) above, and the stated range ends above it.
By their numbers in this assay, from the lowest: compounds 3 and 1 (each within the scatter of the next); then compound 2.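

In this assay, methyl in place of hydrogen on an aromatic carbon of the six-membered aromatic ring of carbon only, part of a fused or bridged system of two rings, gives a 5.4-fold lower number from compound 2 to compound 3 (0.73 log units; beyond the scatter). Within the data shown here, the same swap at a different place on the molecule gave a 5.3-fold higher number from compound 1 to compound 2 (0.72 log units; beyond the scatter), so the one change moves the number in opposite directions at the two places, and the direction of a methyl step depends on where the methyl stands. Nothing available explains this reversal.

Going by these compounds, each place rests on a single step, and it remains open whether the new methyl would lower the number on the core of compound 1 as well. On these data alone, it is also open whether a methoxy group, an amine or a longer chain at this position would move the number the same way.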